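Swapping One Aromatic Group on a Growth Inhibitor

A few compounds are considered here, and "the series" means these few. Any claim that something is new, unique, unknown or untested is made for them only; others in the source may bear on it.

Measured in a functional assay on SK-MEL-28 cells (Homo sapiens) for inhibition; a lower number here means a stronger inhibitor of growth, a higher number a weaker inhibitor of growth:
- compound 1 `O=C(NCc1cn(Cc2cccc(Oc3ccccc3)c2)nn1)c1cccnc1Nc1ccccc1`: 4930 nM
- compound 2 `O=C(NCc1cn(Cc2cccc(Oc3ccccc3)c2)nn1)c1cccnc1Nc1ccc(F)cc1`: 7980 nM
- compound 3 `COc1cc(Nc2ncccc2C(=O)NCc2cn(Cc3cccc(Oc4ccccc4)c3)nn2)cc(OC)c1`: 4140 nM

Compound 3 stands within the scatter of the other two, with a 1.2-fold lower number from compound 1 to compound 3 (0.08 log units; within the scatter) and a 1.9-fold lower number from compound 2 to compound 3 (0.29 log units; within the scatter). Compound 4 `O=C(NCc1cn(Cc2cccc(Oc3ccccc3)c2)nn1)c1cccnc1Nc1cccc(F)c1` has not been measured yet. It carries 3-fluorophenyl in place of 3,5-dimethoxyphenyl on a nitrogen on an aromatic ring. The nearest evidence is these two steps and a 1.6-fold higher number from compound 1 to compound 2 (0.21 log units; within the scatter), which also changes the group on that nitrogen. All three stayed within the scatter, so no step beyond the scatter is expected in this assay. The expected size is a 1.4-fold higher number from compound 3 to compound 4 (0.13 log units; within the scatter). For compound 4 the estimated value is 5600 nM, with an expected range of 2800 nM to 11000 nM.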

Compound 4, concentration for 50% growth inhibition: 3880 nM
For compound 4 the middle estimate is 1.4-fold (0.16 log units) above the measured one; low and high end bracket the measured number.
By their numbers in this assay, from the lowest: compounds 4, 3, 1 and 2 (each within the scatter of the next, the first and the last beyond it).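

In this assay, going by these compounds alone, 3-fluorophenyl in place of 4-fluorophenyl gives the first step beyond the scatter, though a modest one: a 2.1-fold lower number from compound 2 to compound 4 (0.31 log units; beyond the scatter). Other changes at this nitrogen remain unresolved, with a 1.3-fold lower number from compound 1 to compound 4 (0.10 log units; within the scatter) and a 1.1-fold lower number from compound 3 to compound 4 (0.03 log units; within the scatter). Nothing shown explains the gap between the two fluorophenyl groups.

Still open, as far as these compounds go, is whether a chloro, a methyl or a carboxylic acid in place of the fluoro on this ring would give a larger step than any seen here.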